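Adding a Methoxy Group to Compound 2

The source may report more compounds than this note shows. Statements on the series, on what has been measured and on what is new or still open speak of the compounds shown alone.

In an ADME assay on THP-1 cells (Homo sapiens) for cytotoxicity, read by flow cytometry and propidium iodide staining, with a stated time of 72 h (on this read-out higher numbers stand for weaker inhibition and lower numbers for stronger inhibition), compound 1 (`COc1cccc(/C=C/C(=O)c2cc(NC(C)=O)ccc2O)c1`) gives 93700 nM. Compound 2 (`CC(=O)Nc1ccc2oc(-c3ccccc3)cc(=O)c2c1`) gives 97000 nM, the higher number of the two only on paper, since the pair lies within the scatter. Compound 3 (`COc1cccc(-c2cc(=O)c3cc(NC(C)=O)ccc3o2)c1`) differs from compound 2 by methoxy in place of hydrogen on an aromatic carbon. Among the compounds with values here, no measured pair shows this change alone. Compound 1 also carries a methoxy group and gives 93700 nM, so the expected 1.1-fold lower number from compound 2 to compound 3 (0.06 log units; within the scatter) stays within the scatter, with no clear direction. For compound 3, the estimated value is 85000 nM, with an expected range from 40000 nM to 160000 nM.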

Compound 3, half-maximal inhibitory concentration: 10000 nM
The estimate for compound 3 lay 8.5-fold (0.93 log units) above the measured number; the measured number lies below the stated range.
By their numbers in this assay, from the lowest: compound 3; then compounds 1 and 2 (each within the scatter of the next).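

In this assay, methoxy in place of hydrogen on an aromatic carbon, meta to a large group, gives a 9.7-fold lower number from compound 2 to compound 3 (0.99 log units; beyond the scatter), which lies beyond the scatter. Within the data shown here, this is the first pair to show this change alone, and it shows that the read-out responds to a substitution at this position of the six-membered aromatic ring. Nothing measured here accounts for the step.

Going by these compounds, whether a hydroxy group or an amine on the same carbon would give a step of similar size remains open. So does whether methoxy on another carbon of that ring would do the same.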